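Notes on the acyl cap of a sulfonamide series

A few compounds are considered here, and "the series" means these few. Any claim that something is new, unique, unknown or untested is made for them only; others in the source may bear on it.

Compound 1 `O=C(CN1CCNCC1)N1CCC(NS(=O)(=O)c2cc(S(=O)(=O)c3ccccc3)ccc2C(F)(F)F)CC1` and compound 2 `O=C([C@@H]1CCCN1C(=O)c1ccncc1)N1CCC(NS(=O)(=O)c2cc(S(=O)(=O)c3ccccc3)ccc2C(F)(F)F)CC1` share one core and differ only in the group carried on its amide. In a functional assay on U2OS cells for antagonist activity at proto-oncogene Wnt-3 (Homo sapiens), read by a luciferase reporter, with a stated time of 18 h (a higher number here means that more compound is needed for the effect, a lower number that less compound is needed), compound 1 gives 250 nM. In this assay, among the compounds with values here, compound 2 gives 350 nM; set against compound 1, the gap lies within the usual scatter of repeated measurements, so the two numbers read as one level, and no step between measured compounds is at hand. Compound 3 `CN(C)C(=O)N1CCC[C@H]1C(=O)N1CCC(NS(=O)(=O)c2cc(S(=O)(=O)c3ccccc3)ccc2C(F)(F)F)CC1` follows from compound 2 by dimethylamino in place of pyridin-4-yl on a carbonyl carbon. Nothing measured bears on this exchange, so the expected step is a 1.1-fold higher number from compound 2 to compound 3 (0.06 log units; within the scatter), small and in no firm direction, not clearly beyond the scatter. Compound 3 is accordingly estimated at 400 nM, with a range from 150 nM to 1100 nM.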

Compound 3, half-maximal effective concentration: 160 nM
Estimate against measurement, compound 3: 2.5-fold (0.40 log units) above; measured number inside the range.
By their numbers in this assay, from the lowest: compounds 3, 1 and 2 (each within the scatter of the next, the first and the last beyond it).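

On the carbonyl carbon whose other neighbour is the amide-type nitrogen in a ring, dimethylamino in place of pyridin-4-yl gives a 2.2-fold lower number from compound 2 to compound 3 (0.34 log units; beyond the scatter) in this assay, so this position responds to the exchange and the six-membered aromatic ring is not needed to hold activity here. 1-(Dimethylcarbamoyl)pyrrolidin-2-yl in place of (piperazin-1-yl)methyl on a carbonyl carbon gives a 1.6-fold lower number from compound 1 to compound 3 (0.19 log units; within the scatter), which places these two structurally different caps at one level. Nothing at hand gives a reason for either step.

Open, on these data alone, is whether the step belongs to dimethylamino in particular or would also appear with morpholin-4-yl or a plain methyl on the same carbonyl carbon. Also open, as far as these compounds go, is how a free amine on the pyrrolidine, without any carbonyl cap, would compare with compound 3.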